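An Open-Chain Amino Alcohol in Place of a Pyrrolidine

A few compounds are considered here, and "the series" means these few. Any claim that something is new, unique, unknown or untested is made for them only; others in the source may bear on it.

The compounds here were tested in a functional assay on HEK293 cells for negative allosteric modulation of metabotropic glutamate receptor 2 (Rattus norvegicus), read by calcium flux, with a stated time of 2.5 min; a lower number here means a stronger inhibitor, a higher number a weaker inhibitor. Compound 1 has the structure `COc1ccc(C#Cc2ccc(C(=O)N3CCC(CO)C3)cc2)cc1`. In this assay compound 1 gives > 30000 nM, which is a limit of the measurement rather than a number. Compound 2, with the structure `COc1ccc(C#Cc2ccc(C(=O)N3CCC[C@@H](O)C3)cc2F)cc1`, also reaches only a limit in this assay, at > 30000 nM. Compound 3, with the structure `COc1ccc(C#Cc2ccc(C(=O)N3CCC[C@@H](O)C3)c(F)c2)cc1`, likewise gives a limit of > 30000 nM in this assay. For the measured compounds named here, all the data so far therefore rest on (the limit of > 30000 nM in this assay, at which 3 of the 3 values shown sit), and no step between measured compounds can be read from them.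

Compound 4 has the structure `COc1ccc(C#Cc2ccc(C(=O)NC(C)CO)cc2)cc1`. Relative to compound 1 the change is (1-(hydroxymethyl)ethyl)amino in place of 3-(hydroxymethyl)pyrrolidin-1-yl on a carbonyl carbon; the ring on the amide is opened into a short chain that still carries a hydroxyl group. With every measured compound sitting at the same limit there is no pattern that points in either direction, and the expected step from compound 1 to compound 4 is estimated as a number no higher from compound 1 to compound 4 (the limit leaves the size open), that is, nothing beyond the usual scatter. Compound 4 is therefore expected to give about 30000 nM in this assay, with a range from 10000 nM to 100000 nM, and most likely the assay will again report only a limit.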

Compound 4, half-maximal inhibitory concentration: > 30000 nM
Compound 4 ended at the assay's limit; the forecaster's own chance of this, stated with the estimate: 80%; the middle value sits exactly at the limit.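

In this assay compound 4 gives > 30000 nM, which is a limit of the measurement and not a number. For the compounds shown here, compound 1 also sits at a limit, so no step between compound 1 and compound 4 can be read. The compounds shown leave open which structure, if any, would give a measurable value: the limit of > 30000 nM in this assay, at which 4 of the 4 values shown sit.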